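The compounds below may be only part of what the source reports. "The series", "measured", "known", "first", "only" and "open" are said of these compounds alone.

Compound 1 `CCNC(=O)Nc1cccc2c1CN(C)CC2c1ccccc1`: 54 mg/kg
Compound 2 `CCOC(=O)Nc1cccc2c1CN(C)CC2c1ccc(F)cc1`: 3.3 mg/kg

In a functional assay on the whole organism for inhibition, with Mus musculus as the target (on this read-out lower numbers stand for an effect already at smaller amounts and higher numbers for an effect only at larger amounts of compound), compound 1 has the higher of the two numbers at 54 mg/kg, well beyond the scatter from compound 2. Compound 3 `CN1Cc2c(NC(=O)OCc3ccccc3)cccc2C(c2ccccc2)C1` is not yet measured. It has benzyloxy in place of ethylamino on a carbonyl carbon. Within the data shown here, no measured pair differs in only one place, so the size of this step is uncertain. Compound 2 also lacks ethylamino and gives 3.3 mg/kg, although it differs elsewhere too. A step to a lower number in this assay, beyond the scatter, is therefore expected. The estimated change is a 3.9-fold lower number from compound 1 to compound 3 (0.59 log units; beyond the scatter). For compound 3, the estimate is 14 mg/kg, with an expected range of 3 mg/kg to 60 mg/kg.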

Compound 3, dose for half-maximal effect: 16 mg/kg
Estimate against measurement, compound 3: 1.1-fold (0.06 log units) below, within the range that was stated.
By their numbers in this assay, from the lowest: compound 2; then compound 3; then compound 1.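

Among these compounds, putting benzyloxy in place of ethylamino on a carbonyl carbon gives a 3.4-fold lower number from compound 1 to compound 3 (0.53 log units; beyond the scatter) in this assay, the first step here tied to a single place. This position therefore accepts a larger group carrying a six-membered aromatic ring and no hydrogen-bond donor, with the number falling rather than rising. No measured evidence explains the step. The compounds shown leave open whether the oxygen, the ring or the lost donor accounts for it. A benzylamino group on the same carbonyl carbon would keep the ring and the donor without the oxygen.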